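This account rests on a few compounds, and the source may have more. Where it says the series, first, only, none or still open, it means among the compounds named here.

Measured compounds:
Compound 1 `C=CCOc1ccccc1C1CC(=O)c2ccccc2O1` — 47%
Compound 2 `CC(C)=CCOc1ccccc1C1CC(=O)c2ccccc2O1` — 40.3%

Among the compounds with values here, compound 2 carries the lower of the two numbers in a functional assay on J774.A1 cells (Mus musculus) for inhibition, read by immunoassay, with a stated time of 12 h, tested at 30 uM (on this read-out higher numbers stand for more inhibition at the one concentration tested (going by the name of the read-out) and lower numbers for less inhibition), but its only neighbour, compound 1, sits just a number 6.7 percentage points lower from compound 1 to compound 2 (within the scatter) away, which is within the scatter, so the two cannot be ranked against each other. The unmeasured compound 3 `COCOc1ccccc1C1CC(=O)c2ccccc2O1` keeps the shared core and changes only the group on the saturated chain carbon bound to an oxygen on the aromatic ring: methoxy in place of 2-methylprop-1-en-1-yl on a saturated chain carbon bound to an oxygen on an aromatic ring.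

Within the data shown here, only one measured step bears on this position, the step from compound 1 to compound 2, which swapped one chain for another at the same place and gave a number 6.7 percentage points lower from compound 1 to compound 2 (within the scatter). That single step is within the scatter, so the data give no sign that changes at this point move this assay by much. Among the measured compounds shown here, the move to methoxy is a different kind of exchange, with an oxygen entering where only carbon stood, and no measured pair shows its effect; the expectation therefore rests on the one small step seen.

Compound 3 is estimated at 40%, with a range from 20% to 60%, which means an expected step of a number 0.3 percentage points lower from compound 2 to compound 3 (within the scatter) in this assay, not beyond the scatter.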

Compound 3, a percentage reported as inhibition, at one concentration (the size of the read-out at that concentration, not a potency): 33.3%
The estimate for compound 3 lay 6.7 percentage points above the measured number; the measured number falls inside the stated range.
By their numbers in this assay, from the lowest: compounds 3, 2 and 1 (each within the scatter of the next, the first and the last beyond it).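

In this assay, within the data shown here, the replacement of vinyl by methoxy on a saturated chain carbon bound to an oxygen on an aromatic ring gives the only step at this position that clears the scatter: a number 13.7 percentage points lower from compound 1 to compound 3 (beyond the scatter). The same methoxy set against 2-methylprop-1-en-1-yl gives a number 7 percentage points lower from compound 2 to compound 3 (within the scatter), so compound 2 and compound 3 cannot be ranked against each other, just as compound 1 and compound 2 could not. The position is thus not wholly silent in this assay, but the only separation is a modest one between compound 1 and compound 3, with compound 2 unresolved from either. No measurement shown here accounts for this difference between methoxy and vinyl.

The compounds shown leave open whether an amine, a carboxylic acid or a longer chain at this place would move the number further, in either direction. They also leave open whether the gap between compound 1 and compound 3 would hold as a difference in potency, since this assay reports inhibition at one concentration only.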